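Adding a Methyl Group to a Dichlorophenyl Analog

The source may hold more compounds than are shown below. What is called first, only, known or untested is meant among the compounds shown, and "the series" means these compounds.

Of the compounds shown here, three sharing one core have been measured in a functional assay on HL-60 cells (Homo sapiens) for inhibition, read by CCK-8 assay, with a stated time of 48 h; a lower number here means a stronger inhibitor, a higher number a weaker inhibitor. Compound 3 `O=C(NCCNS(=O)(=O)c1sccc1-c1ccccc1Oc1ccc(O)c(O)c1)Nc1cc(Cl)cc(Cl)c1` is the one measured without the methyl group; in this assay compound 3 gives 6900 nM, the highest of the three numbers. Compound 1 `Cc1ccc(-c2ccsc2S(=O)(=O)NCCNC(=S)Nc2ccc([N+](=O)[O-])cc2)c(Oc2ccc(O)c(O)c2)c1` gives 2900 nM in this assay, and compound 2 `Cc1ccc(-c2ccsc2S(=O)(=O)NCCNC(=O)Nc2ccc([N+](=O)[O-])cc2)c(Oc2ccc(O)c(O)c2)c1` gives 3900 nM. Among the measured compounds shown here, the only comparison between compounds differing in one place is a 1.3-fold higher number from compound 1 to compound 2 (0.13 log units; within the scatter), an exchange of one group for another on an amine nitrogen that stays within the scatter. For the measured compounds named here, compound 2 and compound 3 differ in two places at once, so their values show only that compound 3 lies within the scatter of compound 2 while its gap to compound 1 is beyond it.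

Compound 4 `Cc1ccc(-c2ccsc2S(=O)(=O)NCCNC(=O)Nc2cc(Cl)cc(Cl)c2)c(Oc2ccc(O)c(O)c2)c1` arises from compound 3 by methyl in place of hydrogen on an aromatic carbon. No measured pair isolates this change: the methyl group is present in both compound 1 and compound 2, and the one shown step concerns a different part of the molecule, so it says nothing about what the methyl does. With nothing pointing either way, the expected step is no change at the digits printed from compound 3 to compound 4 (within the scatter), that is, no change beyond the scatter. Compound 4 is therefore estimated at 6900 nM, with a range from 2800 nM to 17000 nM.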

Compound 4, half-maximal inhibitory concentration: 3500 nM
Estimate against measurement, compound 4: 2.0-fold (0.29 log units) above; the measured number falls inside the stated range.
By their numbers in this assay, from the lowest: compounds 1, 4, 2 and 3 (each within the scatter of the next, the first and the last beyond it).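

In this assay, methyl in place of hydrogen on this aromatic carbon, meta to the 3,4-dihydroxyphenoxy group and para to a large group, gives a 2.0-fold lower number from compound 3 to compound 4 (0.29 log units; within the scatter) and so stays within the scatter: this single pair offers no firm sign that the added methyl changes inhibition of HL-60 cells. With the methyl present, 3,5-dichlorophenyl in place of 4-nitrophenyl gives a 1.1-fold lower number from compound 2 to compound 4 (0.05 log units; within the scatter) and the exchange of the larger group on the amine nitrogen gives a 1.2-fold higher number from compound 1 to compound 4 (0.08 log units; within the scatter) so compounds 1, 2 and 4 cannot be told apart in this assay, whichever of these groups they carry. Nothing among the available findings offers an explanation for these numbers.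

Among the compounds shown here, only one pair isolates the methyl, so it remains open whether the same change would also stay within the scatter on a compound carrying the 4-nitrophenyl group. As far as these compounds go, it is also open whether an ethyl group, a methoxy group or a chlorine atom on the same aromatic carbon would give a step beyond the scatter.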